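Piperidine substituent change in a geranylgeranyl transferase series

The source may hold more compounds than are shown below. What is called first, only, known or untested is meant among the compounds shown, and "the series" means these compounds.

Measured compounds:
compound 1 `Cn1cncc1C(OCc1ccc(C#N)nc1N1CCN(C(=O)OC(C)(C)C)CC1)c1ccc(C#N)cc1` — 42 nM
compound 2 `Cn1cncc1C(OCc1nc(N2CCC(C(N)=O)CC2)c(C#N)cc1-c1cccc(Cl)c1)c1ccc(C#N)cc1` — 2100 nM
compound 3 `Cn1cncc1C(OCc1ccc(C#N)cc1-c1cccc(Cl)c1)c1ccc(C#N)nc1` — 8620 nM

In an assay on isolated protein (Bos taurus) for inhibition of geranylgeranyl transferase type-1 subunit beta (Homo sapiens) (a lower number here means a stronger inhibitor, a higher number a weaker inhibitor), compound 1 gives 42 nM, compound 2 gives 2100 nM and compound 3 gives 8620 nM. Compound 2 holds the second highest of the three numbers; compound 3 is its nearest neighbour, compound 1 its furthest, and both gaps lie beyond the scatter. Among the compounds with values here, no pair among the three differs in one place only, so no single step is available to calibrate a change on the ring attached to the core.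

Compound 4 `Cn1cncc1C(OCc1nc(N2CCC(O)CC2)c(C#N)cc1-c1cccc(Cl)c1)c1ccc(C#N)cc1` has not yet been measured. It differs from compound 2 in one place: hydroxy in place of carbamoyl on a saturated ring carbon. Within the data shown here, nothing among the measured compounds shows what this change does on its own, so the expectation is for a step of a 1.2-fold higher number from compound 2 to compound 4 (0.08 log units; within the scatter) in this assay, not beyond the scatter in either direction. Compound 4 is estimated at 2500 nM, within a range from 800 nM to 8000 nM.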

Compound 4, half-maximal inhibitory concentration: 830 nM
Estimate against measurement, compound 4: 3.0-fold (0.48 log units) above, and the stated range covers the measured number.
By their numbers in this assay, from the lowest: compound 1; then compound 4; then compound 2; then compound 3.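

Within the data shown here, replacing 4-carbamoylpiperidin-1-yl with 4-hydroxypiperidin-1-yl gives the first single-place step: in this assay it is a 2.5-fold lower number from compound 2 to compound 4 (0.40 log units; beyond the scatter). A change on this saturated ring carbon can therefore move the number beyond the scatter, though only modestly. In this pair, the carbamoyl group with its 3 heavy atoms is not required, since hydroxy gives the lower number, and no available data explain the step.

The compounds shown leave open how an amine, a carboxylic acid or a methoxy group on the same ring carbon would compare with hydroxy. Compound 1 differs from compound 4 in more than one place, so the share of this ring substituent in the gap between them cannot be read.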